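Methyl added to the dimethylcarbamoyl of compound 3

The source may hold more compounds than are shown below. What is called first, only, known or untested is meant among the compounds shown, and "the series" means these compounds.

Compound 3 `CN(C)C(=O)[C@@H]1CN[C@H](C(=O)N2CCC[C@H]2C#N)C1` stands second among the three compounds measured in an assay on the whole organism (plasma, strain Sprague-Dawley) for inhibition of Dipeptidyl peptidase 4 (Rattus norvegicus), with a stated time of 6 h, at a dose of 1 mg/kg by the oral route (on this read-out higher numbers stand for more inhibition at the one dose given (going by the name of the read-out) and lower numbers for less inhibition), where compound 3 gives 76%. Compound 2 `CCN(C)C(=O)[C@H]1C[C@@H](C(=O)N2CCC[C@H]2C#N)N[C@H]1C` gives 92% in this assay, and compound 1 `CCC[C@@H]1CN[C@H](C(=O)N2CCC[C@H]2C#N)C1` gives 50%. For the measured compounds named here, the only single-point step measured is a number 26 percentage points higher from compound 1 to compound 3 (beyond the scatter), which concerns a different change. Compound 4 `CCN(C)C(=O)[C@@H]1CN[C@H](C(=O)N2CCC[C@H]2C#N)C1` differs from compound 3 by methyl in place of hydrogen on a saturated chain carbon bound to an amide-type nitrogen. Going by the values given here, no measured step bears directly on this change; compound 2, which carries ethyl(methyl)carbamoyl on a differently substituted core, gives 92%, so a step within the scatter or a small rise is expected. Compound 4 is estimated at 80% in this assay, between 66% and 92%. The expected step is a number 4 percentage points higher from compound 3 to compound 4 (within the scatter).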

Compound 4, a percentage reported as inhibition, in the whole organism at one dose (the size of the read-out at that dose, not a potency): 71%
Compound 4: middle estimate off by 9 percentage points, on the high side, within the range that was stated.
By their numbers in this assay, from the lowest: compound 1; then compounds 4 and 3 (each within the scatter of the next); then compound 2.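

In this assay, methyl in place of hydrogen on a saturated chain carbon bound to an amide-type nitrogen gives a number 5 percentage points lower from compound 3 to compound 4 (within the scatter) and so leaves no readable change at this position. The higher number of compound 2 therefore does not come with ethyl(methyl)carbamoyl alone: hydrogen in place of methyl on a saturated ring carbon gives a number 21 percentage points lower from compound 2 to compound 4 (beyond the scatter) even with that group present. Ethyl(methyl)carbamoyl in place of propyl still gives a number 21 percentage points higher from compound 1 to compound 4 (beyond the scatter) on the shared core. No evidence explains these differences.

As far as these compounds go, whether a longer chain in place of the ethyl would hold the number stays open, as does a carboxylic acid in place of the carbamoyl.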